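Growing the side chain of compound 3

This account rests on a few compounds, and the source may have more. Where it says the series, first, only, none or still open, it means among the compounds named here.

Of the compounds shown here, three with a shared core have been tested in a functional assay on HCT-116 cells (Homo sapiens) for antiproliferative activity, read by sulforhodamine B assay, with a stated time of 72 h; a higher number here means a weaker inhibitor, a lower number a stronger inhibitor. Compound 3 `Cn1ncc(Cl)c1-c1cc(C(=O)N[C@@H]2CN[C@H](CCO)C[C@H]2c2ccc(Cl)c(Cl)c2)oc1Cl` gives 340 nM, the lowest number of the set. Compound 2 `CN(C)CC[C@@H]1C[C@@H](c2ccc(Cl)c(Cl)c2)[C@H](NC(=O)c2cc(-c3c(Cl)cnn3C)c(Cl)o2)CN1` gives 1710 nM, and compound 1 `Cn1ncc(Cl)c1-c1cc(C(=O)N[C@@H]2CN[C@H](CCN3CCC(O)CC3)C[C@H]2c2ccc(Cl)c(Cl)c2)oc1Cl` gives 13700 nM. They differ only in the group at the end of a saturated chain.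

Compound 4 `Cn1ncc(Cl)c1-c1cc(C(=O)N[C@@H]2CN[C@H](CC(=O)NCCO)C[C@H]2c2ccc(Cl)c(Cl)c2)oc1Cl` has not yet been measured. It carries (2-hydroxyethyl)carbamoyl in place of hydroxymethyl on a saturated chain carbon bound to a saturated ring carbon.

All three measured steps concern this same chain. Replacing dimethylamino with hydroxy gave a 5.0-fold lower number from compound 2 to compound 3 (0.70 log units; beyond the scatter), and replacing 4-hydroxypiperidin-1-yl with hydroxy gave a 40-fold lower number from compound 1 to compound 3 (1.61 log units; beyond the scatter). Replacing 4-hydroxypiperidin-1-yl with dimethylamino gave an 8.0-fold lower number from compound 1 to compound 2 (0.90 log units; beyond the scatter). Among these three compounds the number rises as the end group grows, and none goes against this. None of them carries a carbamoyl group, however, so they offer only a loose guide.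

A modest rise is therefore expected in this assay, with the expected change being a 2.9-fold higher number from compound 3 to compound 4 (0.47 log units; beyond the scatter). For compound 4 the estimated value is 1000 nM, with an expected range of 300 nM to 4000 nM.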

Compound 4, half-maximal inhibitory concentration: 670 nM
The estimate for compound 4 lay 1.5-fold (0.17 log units) above the measured number; low and high end bracket the measured number.
By their numbers in this assay, from the lowest: compounds 3 and 4 (each within the scatter of the next); then compound 2; then compound 1.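

In this assay, the swap of hydroxymethyl for (2-hydroxyethyl)carbamoyl on a saturated chain carbon bound to a saturated ring carbon gives a 2.0-fold higher number from compound 3 to compound 4 (0.29 log units; within the scatter) and so shows that this position can hold a longer group carrying a carbonyl and an amide hydrogen without a change that can be told from the scatter. Compound 4 also goes against the earlier link between a larger end group and a higher number, since its group is longer than the (dimethylamino)methyl of compound 2, yet the data show a 2.6-fold lower number from compound 2 to compound 4 (0.41 log units; beyond the scatter) and, against the (4-hydroxypiperidin-1-yl)methyl of compound 1, a 20-fold lower number from compound 1 to compound 4 (1.31 log units; beyond the scatter) in the same assay; among these four compounds, the two whose chains end in an amine now give the highest numbers, and none goes against this, though nothing available explains why.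

The compounds shown leave open whether the amide or its terminal hydroxy matters more, which a plain carbamoyl group or an N-methyl amide could help separate. They also leave open how a carboxylic acid, or a longer chain ending in hydroxy, would behave at this position.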